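The source may hold more compounds than are shown below. What is called first, only, known or untested is meant among the compounds shown, and "the series" means these compounds.

In a functional assay (B cells) with Mus musculus as the target (a lower number here means that less compound is needed, a higher number that more compound is needed for the effect), compound 3 `CN(C)CCCn1c(=O)n(C2OC(CO)[C@@H](O)[C@H]2O)c2nc(N)nc(O)c21` gives 194 uM, the largest of the three numbers recorded, though compound 2 sits within the usual scatter of it. Compound 2 `COc1ccc(Cn2c(=O)n(C3OC(CO)[C@@H](O)[C@H]3O)c3nc(N)nc(O)c32)cc1` gives 135 uM, and the step of a 1.4-fold higher number from compound 2 to compound 3 (0.16 log units; within the scatter) falls inside that scatter. Within the data shown here, compound 1 `C=CCn1c(=S)n(C2OC(COCc3ccccc3)[C@H]3OC(C)(C)O[C@@H]23)c2nc(N)nc(O)c21` gives 47 uM; no single-change step joins it to compound 3, so its number stands on its own and is the only one beyond the scatter from compound 3.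

Compound 4 `N#Cc1ccc(Cn2c(=O)n(C3OC(CO)[C@@H](O)[C@H]3O)c3nc(N)nc(O)c32)cc1` differs from compound 3 in one place: 4-cyanophenyl in place of 2-(dimethylamino)ethyl on a saturated chain carbon bound to an aromatic nitrogen. Among the measured compounds shown here, the one measured step that bears on this change is a 1.4-fold higher number from compound 2 to compound 3 (0.16 log units; within the scatter), which exchanged a six-membered aromatic ring for the 2-(dimethylamino)ethyl chain at the same place and moved the number only within the scatter. Compound 4 reverses that kind of exchange, so the expected step is a 1.5-fold lower number from compound 3 to compound 4 (0.17 log units; within the scatter), a shift no larger than the scatter. Compound 4 is therefore estimated at 130 uM, with a range from 50 uM to 350 uM.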

Compound 4, concentration for half-maximal effect: 15 uM
The estimate for compound 4 lay 8.7-fold (0.94 log units) above the measured number, outside the stated range (below it).
By their numbers in this assay, from the lowest: compound 4; then compound 1; then compounds 2 and 3 (each within the scatter of the next).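

In this assay, the group at this place, on a saturated chain carbon bound to an aromatic nitrogen, can shift the number strongly: 4-cyanophenyl in place of 2-(dimethylamino)ethyl gives a 13-fold lower number from compound 3 to compound 4 (1.11 log units; beyond the scatter) in this series. A six-membered aromatic ring alone does not account for this, since compound 2 also carries one and stays within the scatter of compound 3, whereas cyano in place of methoxy on an aromatic carbon gives a 9.0-fold lower number from compound 2 to compound 4 (0.95 log units; beyond the scatter) with nothing else changed. No measurement at hand explains why the nitrile has this effect.

From the compounds shown here alone, it remains open whether a chlorine, a trifluoromethyl group or a carboxylic acid in place of the nitrile would give a similarly low number. Going by these compounds, compound 1 differs from compound 4 in several places, so whether the 4-cyanobenzyl group would act the same way on its core also stays unknown.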